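This account rests on a few compounds, and the source may have more. Where it says the series, first, only, none or still open, it means among the compounds named here.

Of the compounds shown here, three share one core and have been tested in an ADME assay on BJ cells (Homo sapiens) for cytotoxicity, read by CellTiter-Glo and resazurin assay, with a stated time of 72 h; on this read-out higher numbers stand for an effect only at larger amounts of compound and lower numbers for an effect already at smaller amounts. Compound 1 `CC(C)N(Cc1cccc(OCCCCCC(=O)O)c1)C(=O)c1ccc(-c2cccc(Oc3ccccc3)c2)cc1` carries a phenoxy group and a free acid chain; in this assay compound 1 reaches only the limit > 18700 nM. Compound 2 `CCOC(=O)CCCCCOc1cccc(CN(C(=O)c2ccc(-c3cccc(C(C)=O)c3)cc2)C(C)C)c1` carries an acetyl group and an ethyl ester chain; in this assay compound 2 gives the limit > 26000 nM. Compound 3 `CCOC(=O)CCCCCOc1cccc(CN(C(=O)c2ccc(-c3cccc(OC(C)C)c3)cc2)C(C)C)c1` carries isopropoxy in place of acetyl on an aromatic carbon; in this assay compound 3 likewise gives the limit > 26000 nM. The step that the two limits leave unreadable from compound 2 to compound 3 therefore cannot be read, since both ends sit at the same limit (the limit of > 26000 nM in this assay, at which 2 of the 3 values shown sit). Compound 3 thus stands at the limit together with compound 2, while compound 1 stands at its own limit (the limit of > 18700 nM in this assay, at which 1 of the 3 values shown sits).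

Compound 4 `CCOC(=O)CCCCCOc1cccc(CN(C(=O)c2ccc(-c3cccc(Oc4ccccc4)c3)cc2)C(C)C)c1` differs from compound 3 by phenyl in place of isopropyl on an oxygen on an aromatic ring. Among the compounds with values here, no measured step follows this change directly, but compound 1, which carries the same phenoxy group with an acid chain, gives only the limit > 18700 nM. The step that the limit leaves unreadable from compound 3 to compound 4 is therefore expected to be unreadable or within the scatter. Compound 4 is expected to give 50000 nM, within 20000 nM to 200000 nM, most likely again only as a limit.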

Compound 4, half-maximal effective concentration: > 19600 nM
Compound 4: only a limit was reported; the forecaster's own chance of this, stated with the estimate: 85%; the middle value lies beyond the limit too.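

Compound 4 gives only a limit, as do compound 1, compound 2 and compound 3, and the steps from these three to compound 4 cannot be read. The compounds shown leave open at what concentration any of the four would show an effect, and whether exchanging acetyl, isopropoxy or phenoxy changes it.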